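The compounds below may be only part of what the source reports. "The series", "measured", "known", "first", "only" and "open" are said of these compounds alone.

Of the compounds shown here, three have been measured in a functional assay on COLO 205 cells (Homo sapiens) for cytotoxicity, read by sulforhodamine B assay, with a stated time of 48 h, tested at 100 uM; on this read-out lower numbers stand for a stronger effect and higher numbers for a weaker effect at the one concentration tested. Compound 1 `COc1cc(-c2cc(/C=C/C(=O)c3ccc(N)cc3)[nH]n2)cc(OC)c1OC` gives -78% in this assay. Compound 2 `COc1ccc(-c2cc(/C=C/C(=O)c3ccc(N)cc3)[nH]n2)cc1OC` gives -78% in this assay. Compound 3 `COc1cc(C(=O)/C=C/c2cc(-c3cc(OC)c(OC)c(OC)c3)n[nH]2)cc(OC)c1OC` has a core that differs from that of compound 1 in a way that is not broken down here; in this assay compound 3 gives -100%, the lowest of the three numbers and beyond the scatter from both others.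

From compound 1 to compound 2 the change is hydrogen in place of methoxy on an aromatic carbon, and the step in this assay is no change at the digits printed from compound 1 to compound 2 (within the scatter). The same change, (hydrogen in place of methoxy on an aromatic carbon), leads from compound 3 to the not yet measured compound 4 `COc1ccc(-c2cc(/C=C/C(=O)c3cc(OC)c(OC)c(OC)c3)[nH]n2)cc1OC`; the place where it happens is described in identical words for both pairs, so it is the same change on a different core. Going by the values given here, the change occurs twice in this set, and its one measured instance produced no step beyond the scatter.

Because the measured step of no change at the digits printed from compound 1 to compound 2 (within the scatter) was flat, compound 4 is expected to stay close to compound 3 in this assay, with an expected step of a number 5 percentage points higher from compound 3 to compound 4 (within the scatter). A reading that already sits at full effect leaves little room to fall further, so the estimate for compound 4 in this assay is -95%, expected to lie between -105% and -75%.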

Compound 4, a percentage reported as activity, at one concentration (the size of the read-out at that concentration, not a potency): -88%
For compound 4 the middle estimate is 7 percentage points below the measured one, within the range that was stated.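

In this assay, putting hydrogen in place of methoxy on the core of compound 3 gives a real but small step, a number 12 percentage points higher from compound 3 to compound 4 (beyond the scatter), so on this core the effect at the one concentration tested becomes somewhat weaker. Set beside the earlier instance of the same change, no change at the digits printed from compound 1 to compound 2 (within the scatter), the two steps cannot be told apart: the same change on two cores in this assay, no change at the digits printed (within the scatter) from compound 1 to compound 2 and a number 12 percentage points higher (beyond the scatter) from compound 3 to compound 4, 12 percentage points apart, within the scatter of two such steps. This shows that the change behaves alike on these two cores as far as this read-out can tell, but one step being beyond the scatter and the other within it is no evidence that the cores respond differently, and two pairs at a single concentration do not establish a rule for other cores in the series or give any measure of potency.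

The compounds shown leave open whether a hydroxy group, a chlorine atom or a longer ethoxy chain at this place on the aromatic ring would behave as hydrogen does here. They also leave open whether the same small or absent steps would hold at lower concentrations, where a reading close to full effect would have more room to separate the compounds.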